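Chloro step on the benzyl ring of compound 3

This account rests on a few compounds, and the source may have more. Where it says the series, first, only, none or still open, it means among the compounds named here.

Measured so far:
compound 1 `Cc1ccc(COc2ccc(-c3nn(CCC#N)c(=S)o3)cc2)cc1` — 400 nM
compound 2 `CC(C#N)n1nc(-c2ccc(OCc3ccccc3)cc2)oc1=O` — 48000 nM
compound 3 `N#CCCN1N=C(c2ccc(OCc3ccccc3)cc2)OCC1=O` — 18 nM

Three compounds have been run in an assay for inhibition of Amine oxidase [flavin-containing] B (Rattus norvegicus); a lower number here means a stronger inhibitor, a higher number a weaker inhibitor. Compound 3 gives the lowest number of the three; its nearest neighbour is compound 1, whose value lies well beyond the scatter above it, and compound 2 stands far higher still. No two of these compounds differ in one place only, so the gaps between them are read as values side by side, not as single steps. On the numbers shown, compound 3 is the strongest inhibitor of the set in this assay.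

Compound 4 `N#CCCN1N=C(c2ccc(OCc3ccc(Cl)cc3)cc2)OCC1=O` is the next compound for this assay. It keeps the whole of compound 3 and differs in one place: chloro in place of hydrogen on an aromatic carbon. Among the measured compounds shown here, nothing in the measured set isolates this kind of change, so no counted step can be quoted for it. The expectation is a small step, downward or within the scatter, since compound 3 already gives 18 nM in this assay. The estimated step from compound 3 to compound 4 is a 1.5-fold lower number from compound 3 to compound 4 (0.18 log units; within the scatter). Compound 4 is expected to give 12 nM, with a range of 3 nM to 60 nM.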

Compound 4, half-maximal inhibitory concentration: 100 nM
Compound 4: middle estimate off by 8.3-fold (0.92 log units), on the low side, outside the stated range (above it).
By their numbers in this assay, from the lowest: compound 3; then compound 4; then compound 1; then compound 2.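

In this assay the change from benzyl to 4-chlorobenzyl gives a 5.6-fold higher number from compound 3 to compound 4 (0.74 log units; beyond the scatter) and marks this position on the six-membered aromatic ring as one where a single chloro in place of hydrogen moves the number beyond the scatter, towards a weaker inhibitor. Among the compounds shown here, this is the first one-place comparison, since the earlier compounds all differ from one another in more than one place and could not separate a change on this ring from changes elsewhere in the structure. No measurement at hand accounts for the size or direction of this step.

For the compounds shown here, the single pair speaks only for chloro at this one carbon, on the core shared by compound 3 and compound 4, and sets no trend for the ring as a whole. Still open, from the compounds shown here alone, is whether a fluoro, a bromo or a methoxy group on the same carbon would give a step of similar size, and whether chloro on another carbon of this ring would behave in the same way.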